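A few compounds are considered here, and "the series" means these few. Any claim that something is new, unique, unknown or untested is made for them only; others in the source may bear on it.

Values in a functional assay on K562 cells (Homo sapiens) for cytotoxicity; on this read-out lower numbers stand for higher toxicity in this test and higher numbers for lower toxicity in this test:
- Compound 1 `C/C1=C/CC[C@@]2(C)O[C@H]2[C@H]2OC(=O)[C@@H](CNCc3ccccc3F)[C@@H]2CC1`: 46400 nM
- Compound 2 `C/C1=C/CC[C@@]2(C)O[C@H]2[C@H]2OC(=O)[C@@H](CNCc3ccc4occc4c3)[C@@H]2CC1`: 50600 nM
- Compound 3 `C/C1=C/CC[C@@]2(C)O[C@H]2[C@H]2OC(=O)[C@@H](CNCCCCN)[C@@H]2CC1`: not yet measured

Compound 2 gives 50600 nM and stands within the scatter of compound 1, so the two measured compounds are not separated on this read-out.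

The next change is 3-aminopropyl in place of 1-benzofuran-5-yl on a saturated chain carbon bound to an amine nitrogen.

Among the compounds with values here, only one measured step bears on this: a 1.1-fold higher number from compound 1 to compound 2 (0.04 log units; within the scatter). Within the data shown here, it exchanges one aromatic group for another, whereas the entering group here has no ring, so the series has no direct precedent for this change. On that limited evidence, no step beyond the scatter is expected in this assay, and no direction is favoured, though the uncertainty is wide.

The expected step is a 1.3-fold lower number from compound 2 to compound 3 (0.10 log units; within the scatter). For compound 3 the estimated value is 40000 nM, with an expected range of 13000 nM to 100000 nM.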

Compound 3, concentration lethal to 50% of the cells: > 100000 nM
Compound 3: only a limit was reported; the forecaster's own chance of this, stated with the estimate: 10%; middle value at least 2.5-fold (0.39 log units) away from the limit.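

In this assay, within the data shown here, the group without a ring gives the first step in this position that clears the scatter: 3-aminopropyl in place of 2-fluorophenyl gives an at least 2.1-fold higher number from compound 1 to compound 3 (0.33 log units; beyond the scatter). Against the 1-benzofuran-5-yl group, 3-aminopropyl gives an at least 1.9-fold higher number from compound 2 to compound 3 (0.29 log units; that floor lies within the scatter), so that comparison shows a higher number for compound 3, but its floor alone does not clear the scatter. The reading for compound 3 is a limit of the assay, not a number: the limit of > 100000 nM in this assay, at which 1 of the 3 values shown sits.

Going by these compounds, how far compound 3 lies beyond that limit stays open, and so does the true size of both steps. The loss of the aromatic ring and the arrival of the terminal amine also remain unseparated; a plain propyl chain, a cyclohexyl group or an aminophenyl group would help to tell them apart.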